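Nicotinoyl phenol series: chloro removal and allyl ether

The compounds below may be only part of what the source reports. "The series", "measured", "known", "first", "only" and "open" are said of these compounds alone.

Measured so far:
compound 1, `O=C(c1cccnc1)c1cc(Cl)cc(Cl)c1O`, 28700 nM
compound 2, `O=C(c1cccnc1)c1cc(Cl)ccc1O`, 24800 nM
compound 3, `C=CCOc1ccc(Cl)cc1C(=O)c1cccnc1`, > 100000 nM

In a functional assay on PC-3 cells (Homo sapiens) for cytotoxicity, read by sulforhodamine B assay, with a stated time of 48 h (on this read-out lower numbers stand for stronger inhibition and higher numbers for weaker inhibition), compound 1 gives 28700 nM and compound 2 gives 24800 nM. The change between them is hydrogen in place of chloro on an aromatic carbon, and the step is a 1.2-fold lower number from compound 1 to compound 2 (0.06 log units; within the scatter). For compound 3 this assay reports only a limit, > 100000 nM; this is the limit described by the limit of > 100000 nM in this assay, at which 1 of the 3 values shown sits. The step into compound 3 is an at least 4.0-fold higher number from compound 2 to compound 3 (0.60 log units; beyond the scatter). The difference between the core of compound 1 and the core of compound 3 is not broken down here.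

Compound 4, `C=CCOc1ccccc1C(=O)c1cccnc1`, is not yet measured. Its difference from compound 3 is hydrogen in place of chloro on an aromatic carbon. This is the same kind of change as that from compound 1 to compound 2, though the surroundings differ: in compound 1 the chloro that leaves sits ortho to a hydroxy group and meta to a chloro group, while in compound 3 it sits para to an allyloxy group.

Given that compound 3 sits at the assay limit, compound 4 is expected to remain there as well, so that this assay most likely again reports only a limit for compound 4. The step expected for compound 4 is a step that the limit leaves unreadable from compound 3 to compound 4, resting on the step of a 1.2-fold lower number from compound 1 to compound 2 (0.06 log units; within the scatter), where the same kind of change stayed within the scatter. The estimate for compound 4 in this assay is 150000 nM, between 50000 nM and 500000 nM.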

Compound 4, half-maximal inhibitory concentration: 55000 nM
For compound 4 the middle estimate is 2.7-fold (0.44 log units) above the measured one; the range from low to high includes it.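

In this assay, taking chloro off the allyl ether core gives an at least 1.8-fold lower number from compound 3 to compound 4 (0.25 log units; that floor lies within the scatter), and compound 4 returns a readable value of 55000 nM. The value of compound 3, > 100000 nM, is a limit of the assay and not a number, so this step has a floor but no fixed size. The change from chloro to hydrogen has now been seen on two cores, at different places on the ring, but these data cannot show whether its size carries from one core to the other: the same change on two cores in this assay, a 1.2-fold lower number (0.06 log units; within the scatter) from compound 1 to compound 2 and an at least 1.8-fold lower number (0.25 log units; that floor lies within the scatter) from compound 3 to compound 4; the limit leaves it open whether they differ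

Still open, on these data alone, is how the change from hydrogen to allyl on the phenol oxygen reads on the chloro-free core, and whether a methyl ether, a longer chain or a chain ending in an amine on that oxygen would give a value different from that of the allyl ether. Also open, as far as these compounds go, is what bromo or a carboxylic acid would give in the place para to an allyloxy group, where the chloro of compound 3 stands.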